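A few compounds are considered here, and "the series" means these few. Any claim that something is new, unique, unknown or untested is made for them only; others in the source may bear on it.

Within the data shown here, compound 2 `NS(=O)(=O)c1ccc(NC(=S)Nc2ccc3ncnc(Nc4cccc(Br)c4)c3c2)cc1` gives 20700 nM in a functional assay on A-431 cells (Homo sapiens) for antiproliferative activity, read by MTT assay, with a stated time of 72 h (on this read-out lower numbers stand for stronger inhibition and higher numbers for weaker inhibition), the lowest of the two numbers measured so far; its nearest neighbour, compound 1 `NS(=O)(=O)c1ccc(NC(=S)Nc2ccc3ncnc(Nc4ccc(F)c(Cl)c4)c3c2)cc1`, gives 37600 nM, and the step of a 1.8-fold lower number from compound 1 to compound 2 (0.26 log units; within the scatter) is within the scatter. Compound 3 `NS(=O)(=O)c1ccc(NC(=S)Nc2ccc3ncnc(Nc4cccc(Cl)c4F)c3c2)cc1` differs from compound 2 by 3-chloro-2-fluorophenyl in place of 3-bromophenyl on a nitrogen on an aromatic ring. Among the measured compounds shown here, only that one step, from compound 1 to compound 2, bears on this change, and it stayed within the scatter, so the step of a 1.4-fold higher number from compound 2 to compound 3 (0.16 log units; within the scatter) is expected to stay within the scatter too. Compound 3 is therefore estimated at 30000 nM in this assay, within a range of 12000 nM to 75000 nM.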

Compound 3, half-maximal inhibitory concentration: 13100 nM
Beside the measured number, compound 3's estimate is 2.3-fold (0.36 log units) above it, within the range that was stated.
By their numbers in this assay, from the lowest: compounds 3, 2 and 1 (each within the scatter of the next, the first and the last beyond it).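

In this assay the change reads as a 1.6-fold lower number from compound 2 to compound 3 (0.20 log units; within the scatter) and so does not separate 3-chloro-2-fluorophenyl from 3-bromophenyl on this nitrogen. Among these compounds, the comparison of the two chlorine-and-fluorine phenyl groups reads as a 2.9-fold lower number from compound 1 to compound 3 (0.46 log units; beyond the scatter) and is the only step here beyond the scatter, showing that the arrangement of the same two halogens on the ring can change the number modestly. Nothing available explains this difference. The compounds shown leave open whether a phenyl ring carrying an amine or a carboxylic acid would fare differently on this nitrogen, and all three numbers remain high.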